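The source may hold more compounds than are shown below. What is called first, only, known or untested is meant among the compounds shown, and "the series" means these compounds.

Working notes on the series. The shared core of compound 1 `CCn1nc(C)c2c(C)cc(=O)oc21` is varied only at the substituent on an aromatic nitrogen. In a functional assay on the whole organism with Mus musculus as the target, in the writhing test (on this read-out lower numbers stand for an effect already at smaller amounts and higher numbers for an effect only at larger amounts of compound), compound 1 gives 24.9 mg/kg and so has the lowest of the two numbers shown; the nearest is compound 2 `Cc1cc(=O)oc2nn(C(C)C)c(C)c12`, which in this assay gives 35.3 mg/kg, within the scatter of compound 1. Compound 3 `Cc1cc(=O)oc2nn(CCO)c(C)c12` carries a 2-hydroxyethyl group, and in this assay it reaches only the limit > 100 mg/kg, not a number. Going by the values given here, the single step available, an at least 2.8-fold higher number from compound 2 to compound 3 (0.45 log units; beyond the scatter), concerns the hydroxyethyl replacement and rests on (the limit of > 100 mg/kg in this assay, at which 1 of the 3 values shown sits).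

Compound 4 `Cc1cc(=O)oc2c1c(C)nn2C(C)C` is the next member to be measured. Relative to compound 1 the change is methyl in place of hydrogen on a saturated chain carbon bound to an aromatic nitrogen and a saturated chain carbon. Among the compounds with values here, no measured step covers ethyl to isopropyl directly; compound 2 also carries an isopropyl on an aromatic nitrogen, though on a differently arranged core, and its value stands within the scatter of compound 1. The hydroxyethyl step does not bear on a plain alkyl enlargement. The expectation is therefore no step beyond the scatter, a 1.2-fold higher number from compound 1 to compound 4 (0.08 log units; within the scatter). Compound 4 is expected to give 30 mg/kg in this assay, with a range from 14 mg/kg to 65 mg/kg.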

Compound 4, dose for half-maximal effect: > 100 mg/kg
Compound 4: only a limit was reported; the forecaster's own chance of this, stated with the estimate: 5%; at least 3.3-fold (0.52 log units) between middle value and limit.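

On the core of compound 1, ethyl to isopropyl, with methyl in place of hydrogen on a saturated chain carbon bound to an aromatic nitrogen and a saturated chain carbon, gives in this assay an at least 4.0-fold higher number from compound 1 to compound 4 (0.60 log units; beyond the scatter). Compound 4 gives > 100 mg/kg, which is a limit and not a number. The substituent on an aromatic nitrogen thus answers to an added methyl, a plain alkyl change, where the earlier step concerned only the hydroxyethyl replacement, and the full size of the new step cannot be read from a limit: the limit of > 100 mg/kg in this assay, at which 2 of the 4 values shown sit.

Going by these compounds, what stays open is whether a methyl or a hydrogen on the aromatic nitrogen, a propyl chain or a cyclopropyl ring would keep the read-out of compound 1 or lose it as well. Also open, on these data alone, is how an amine or a carboxylic acid at the end of the ethyl chain would read on this same core, and how sharply the read-out turns between ethyl and isopropyl.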